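Swapping Phenyl for Naphthalen-2-yl in Compound 3

A few compounds are considered here, and "the series" means these few. Any claim that something is new, unique, unknown or untested is made for them only; others in the source may bear on it.

Of the compounds shown here, three built on one shared core have been tested in an assay on isolated protein for displacement of a labelled ligand from Motilin receptor (Homo sapiens); a lower number here means a stronger inhibitor, a higher number a weaker inhibitor. Compound 1 `CCC[C@@H]1NC(=O)[C@@H](C(C)C)NC(=O)[C@@H](CCCCN)NCCOc2ccccc2/C=C/CNC1=O` gives only a limit in this assay, > 10000 nM. Compound 2 `CCC[C@@H]1NC(=O)[C@@H](C(C)C)NC(=O)[C@@H](Cc2ccc(O)cc2)NCCCCc2ccccc2CCNC1=O` gives 6060 nM. Compound 3 `CCC[C@@H]1NC(=O)[C@@H](C(C)C)NC(=O)[C@@H](Cc2ccccc2)NCCOc2ccccc2CCCNC1=O` gives 57 nM, the lowest of the two numbers, and its nearest neighbour compound 2 sits far higher, a gap beyond the usual scatter. Compound 4 `CCC[C@@H]1NC(=O)[C@@H](C(C)C)NC(=O)[C@@H](Cc2ccc3ccccc3c2)NCCOc2ccccc2CCCNC1=O` has not yet been measured; it differs from compound 3 by naphthalen-2-yl in place of phenyl on a saturated chain carbon bound to a saturated ring carbon. Going by the values given here, no measured pair shows this particular change, so only a modest step is expected in this assay, a 1.4-fold lower number from compound 3 to compound 4 (0.15 log units; within the scatter), with no firm view on its direction. Compound 4 is therefore expected to give about 40 nM, within a range from 8 nM to 250 nM.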

Compound 4, inhibition constant: 79 nM
Compound 4: middle estimate off by 2.0-fold (0.30 log units), on the low side; the measured number falls inside the stated range.
By their numbers in this assay, from the lowest: compounds 3 and 4 (each within the scatter of the next); then compound 2. At a limit, above all of these: compound 1.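

Going by these compounds alone, this is the first pair in the set that differs in one place only. With a 1.4-fold higher number from compound 3 to compound 4 (0.14 log units; within the scatter) in this assay, naphthalen-2-yl does as well as phenyl on a saturated chain carbon bound to a saturated ring carbon, so the added six-membered aromatic ring brings no clear gain or loss in binding.

Going by these compounds, whether an amine or a carboxylic acid in place of phenyl would be accepted at this position remains open. Nothing shown here explains why the larger ring leaves the number within the scatter.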